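This account rests on a few compounds, and the source may have more. Where it says the series, first, only, none or still open, it means among the compounds named here.

In a functional assay on the whole organism for inhibition, with Rattus norvegicus as the target, with stated times of 1 h and 3.5 h, at a dose of 100 mg/kg by the oral route (a lower number here means less inhibition, a higher number more inhibition at the dose given (going by the name of the read-out)), the compounds are compared at a single dose, and the first pair shares an open core. Compound 1 `CC(C)(C)c1nc(N)ncc1-c1ccccc1` gives 46% in this assay, and compound 2 `CC(C)(C)c1ncncc1-c1ccccc1` gives 48%. The two differ by one change, (hydrogen in place of amino on an aromatic carbon), and the step of a number 2 percentage points higher from compound 1 to compound 2 (within the scatter) leaves the read-out essentially unmoved.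

Compound 3 `Nc1ncc2c(n1)CCCCCCCCCC2` is built on a different core, in which the same kind of six-membered aromatic ring with two nitrogens is part of a fused system of two rings; how this core differs from the core of compound 1 is not broken down here. For compound 3 the value in this assay is a limit, not a number: < 5%. This is the lower limit of the assay, (the limit of < 5% in this assay, at which 1 of the 3 values shown sits), and one of the three values shown sits at it.

Compound 4 `c1ncc2c(n1)CCCCCCCCCC2` has not yet been measured. It stands to compound 3 as compound 2 stands to compound 1: the change is hydrogen in place of amino on an aromatic carbon. It is the same kind of change as that from compound 1 to compound 2, though its surroundings differ, being meta to a fused ring and para to a fused ring rather than meta to a tert-butyl group and para to a group of six heavy atoms. Since the step from compound 1 to compound 2 was within the scatter, the same kind of change on compound 3 is expected to make a small step, a number no lower from compound 3 to compound 4 (the limit leaves the size open), and compound 4 is expected to land near 5%, roughly between 0% and 15%, most likely again reported as a limit.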

Compound 4, a percentage reported as inhibition, in the whole organism at one dose (the size of the read-out at that dose, not a potency): < 5%
Compound 4 gave a limit, no number (the forecaster's own chance of this, stated with the estimate: 60%); the middle value sits exactly at the limit.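

In this assay compound 4 gives < 5%, which is a limit and not a number. Compound 3 and compound 4 both stand at a limit, and the step from one to the other cannot be read: the limit of < 5% in this assay, at which 2 of the 4 values shown sit.

The compounds shown leave open whether hydrogen in place of amino on an aromatic carbon changes the read-out at all on the core of compound 3.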